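The source may hold more compounds than are shown below. What is called first, only, known or untested is meant among the compounds shown, and "the series" means these compounds.

Measured so far:
- compound 1 `COc1ccc(-c2cc3ccccc3c(-c3ccc(OC)cc3)n2)cc1` gives 0%
- compound 2 `COc1cc(OC)cc(-c2cc3ccccc3c(-c3ccc(O)cc3)n2)c1` gives 0%
- compound 3 `COc1ccc(-c2cc3cc(C)ccc3c(-c3cccc(O)c3)n2)c(C)c1` gives 73.4%

All three values come from an assay on isolated protein for inhibition of DNA topoisomerase 1 (Homo sapiens), with a stated time of 30 min, tested at 100 uM; a higher number here means a stronger effect of the compound at the concentration tested, a lower number a weaker effect. Compound 1 and compound 2 show no measurable effect, and their two values lie within the scatter of each other, so nothing separates them. Compound 3 stands highest of the three numbers, and its margin over compound 1 and over compound 2 is in each case beyond the scatter, so compound 3 is the active member of this set. Among the measured compounds shown here, no step between two measured compounds differing in a single place is available, so the size of effect that one change can bring is not yet known here.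

Compound 4 `COc1ccc(-c2cc3cc(C)ccc3c(-c3cccc(N)c3)n2)c(C)c1` is the next compound for this assay . Relative to compound 3 the change is amino in place of hydroxy on an aromatic carbon. The swap keeps the count of heavy atoms, donors and acceptors unchanged, and nothing in the measured compounds speaks to this particular exchange, so the expected step is small, within the scatter or a modest fall. The step of a number 13.4 percentage points lower from compound 3 to compound 4 (beyond the scatter) is expected to be small. Compound 4 is estimated at 60%, with a range from 30% to 85%.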

Compound 4, a percentage reported as inhibition, at one concentration (the size of the read-out at that concentration, not a potency): 79.7%
Compound 4: middle estimate off by 19.7 percentage points, on the low side; the range from low to high includes it.
By their numbers in this assay, from the lowest: compounds 1 and 2 (each within the scatter of the next); then compounds 3 and 4 (each within the scatter of the next).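

In this assay, among the compounds shown here, the exchange of 3-hydroxyphenyl for 3-aminophenyl gives a number 6.3 percentage points higher from compound 3 to compound 4 (within the scatter) and is the first step that changes a single place, so the two groups cannot be told apart on this aromatic carbon of the six-membered ring. Within this pair the read-out therefore does not rest on the oxygen of the hydroxy group, since compound 4 at 79.7% carries nitrogen there and stays level with compound 3 within the usual scatter. This holds for these two compounds at the single tested concentration and gives a read-out of effect size, not a potency, and no measurement at hand offers a reason for the match.

Going by these compounds, whether a methoxy group, an acetamido group, a carboxylic acid or a bare hydrogen on this same carbon would keep the read-out stays open, so the need for any substituent here is still unknown. On these data alone, compound 1 and compound 2 each differ from compound 3 in more than one place, so which of those differences matters also remains open.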